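Swapping the imidazolylmethyl arm for a methylcarbamoyl group

This account rests on a few compounds, and the source may have more. Where it says the series, first, only, none or still open, it means among the compounds named here.

The three compounds share one core and differ only in the group hanging from a saturated ring carbon. Compound 1 `O=C1O[C@@H](CN2CCC(c3ccc(F)cc3)CC2)CN1c1ccc(-n2cc(-c3ccccn3)cn2)c(F)c1` carries a piperidine-bearing side chain, compound 2 `O=C1O[C@@H](Cn2ccnc2)CN1c1ccc(-n2cc(-c3ccccn3)cn2)c(F)c1` an imidazole-bearing one, and compound 3 `CNC(=O)[C@H]1CN(c2ccc(-n3cc(-c4ccccn4)cn3)c(F)c2)C(=O)O1` a short amide.

The measure here is an ADME assay on L02 cells (Homo sapiens) for cytotoxicity, read by MTT assay, with a stated time of 48 h; on this read-out lower numbers stand for stronger inhibition and higher numbers for weaker inhibition. In this assay, among the measured compounds shown here, compound 2 gives 350 ug/mL, the only plain number so far. For compound 1 the assay returned only a limit, > 400 ug/mL, so no exact number is known for it. Both readings point to weak cytotoxicity, and the limit of > 400 ug/mL in this assay, at which 1 of the 2 values shown sits, marks where compound 1 sits.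

Going from compound 2 to compound 3, the change is methylcarbamoyl in place of (1H-imidazol-1-yl)methyl on a saturated ring carbon. For the measured compounds named here, no measured pair shows what this kind of swap does on this assay, so the expectation rests on the two values alone.

The step from compound 2 to compound 3 is expected to be small, a 1.1-fold higher number from compound 2 to compound 3 (0.02 log units; within the scatter), and most likely within the usual scatter, with a real chance that compound 3 again returns only a limit. For compound 3 the estimate is 370 ug/mL, within 180 ug/mL to 400 ug/mL.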

Compound 3, half-maximal inhibitory concentration: 217 ug/mL
For compound 3 the middle estimate is 1.7-fold (0.23 log units) above the measured one; low and high end bracket the measured number.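

Moving from the (1H-imidazol-1-yl)methyl arm to methylcarbamoyl in this assay gives a 1.6-fold lower number from compound 2 to compound 3 (0.21 log units; within the scatter), so this assay does not separate the two compounds. On this saturated ring carbon, next to the ring oxygen, the five-membered aromatic ring can therefore give way to a short, ring-free amide that carries a hydrogen-bond donor, with no step beyond the usual scatter. Compound 1 remains a limit, and its steps to the other two compounds cannot be read: the limit of > 400 ug/mL in this assay, at which 1 of the 3 values shown sits.

The compounds shown leave open what a carboxylic acid, a primary amine or a longer chain on this carbon would do in this assay, and whether any such group would give a step beyond the scatter. They also cannot show whether the amide hydrogen of methylcarbamoyl matters at all, a question that a dimethylcarbamoyl group, which has no such hydrogen, could address directly when set against compound 3.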